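Swapping a vinyl for a thiophene ring on a thiophene core

The source may hold more compounds than are shown below. What is called first, only, known or untested is meant among the compounds shown, and "the series" means these compounds.

Measured so far:
Compound 1, `C=Cc1ccsc1CN[C@@H]1C[C@H]2C[C@@H]([C@H]1C)C2(C)C`: 50000 nM
Compound 2, `CCCc1csc(CN[C@@H]2C[C@H]3C[C@@H]([C@H]2C)C3(C)C)c1`: 12500 nM

Both numbers come from an ADME assay on MDCK cells (Canis lupus familiaris) for cytotoxicity, read by microscopy, with a stated time of 48 h; a higher number here means that more compound is tolerated, a lower number that less compound is tolerated. Compound 1 stands highest of the two, and compound 2 sits a good way lower, beyond the usual scatter. Compound 3, `C[C@H]1[C@H](NCc2sccc2-c2ccsc2)C[C@H]2C[C@@H]1C2(C)C`, has not been measured. It differs from compound 1 in one place: thiophen-3-yl in place of vinyl on an aromatic carbon. Going by the values given here, no measured pair shows this kind of change, so the direction is uncertain. A modest step toward less tolerance seems likely, and the expected step of a 2.0-fold lower number from compound 1 to compound 3 (0.30 log units; within the scatter) reflects that. Compound 3 is thus expected to give about 25000 nM, within a range from 8000 nM to 60000 nM.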

Compound 3, minimum cytotoxic concentration: 12500 nM
The estimate for compound 3 lay 2.0-fold (0.30 log units) above the measured number; measured number inside the range.
By their numbers in this assay, from the lowest: compounds 2 and 3 (each within the scatter of the next); then compound 1.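

On this aromatic carbon, two ring bonds from the ring sulfur, thiophen-3-yl in place of vinyl gives a 4.0-fold lower number from compound 1 to compound 3 (0.60 log units; beyond the scatter) in this assay. This is the first change in a single place among these compounds, and it shows that the group at this carbon can shift how much compound the cells tolerate. No measurement here gives a reason for this step. As far as these compounds go, whether the ring sulfur matters remains open, and a phenyl ring at this carbon would test that. An ethyl chain or an amine there could show how other groups compare with vinyl.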